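One Linking Group Swapped in a Dog Dose Study

The source may hold more compounds than are shown below. What is called first, only, known or untested is meant among the compounds shown, and "the series" means these compounds.

Compound 2 `OC(CSc1ncnc2[nH]cnc12)CN1CCN(C(c2ccc(F)cc2)c2ccc(F)cc2)CC1` and compound 1 `OC(CSc1[nH]cnc2ncnc1-2)CN1CCN(C(c2ccccc2)c2ccc(Cl)cc2)CC1` share a common core and differ in their pendant groups. In a functional assay on the whole organism with Canis familiaris (Canis lupus familiaris) as the target (on this read-out higher numbers stand for an effect only at larger amounts of compound and lower numbers for an effect already at smaller amounts), compound 2 gives 0.15 mg/kg, the lower of the two numbers, while compound 1 gives 0.49 mg/kg, a gap beyond the usual scatter. Compound 3 `OC(CNc1[nH]cnc2ncnc1-2)CN1CCN(C(c2ccc(F)cc2)c2ccc(F)cc2)CC1` is not yet measured in this assay. It differs from compound 2 by a group of 10 heavy atoms (5 carbon, 5 nitrogen; one five-membered aromatic ring with 2 hetero atoms, one six-membered aromatic ring with 2 hetero atoms) in place of a group of 10 heavy atoms (5 carbon, 4 nitrogen, 1 sulfur; one five-membered aromatic ring with 2 hetero atoms, one six-membered aromatic ring with 2 hetero atoms), on a saturated chain carbon, two bonds along the chain from an oxygen on a saturated carbon. Among the measured compounds shown here, no measured pair shows this exchange, so only a small step is expected, perhaps a modest move toward a higher number, as a 1.7-fold higher number from compound 2 to compound 3 (0.22 log units; within the scatter). Compound 3 is therefore estimated at 0.25 mg/kg, within 0.08 mg/kg to 0.8 mg/kg.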

Compound 3, dose for half-maximal effect: 0.28 mg/kg
The estimate for compound 3 lay 1.1-fold (0.05 log units) below the measured number; measured number inside the range.
By their numbers in this assay, from the lowest: compounds 2, 3 and 1 (each within the scatter of the next, the first and the last beyond it).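

At this place, on a saturated chain carbon, two bonds along the chain from an oxygen on a saturated carbon, exchanging the group with 1 sulfur for the one with 5 nitrogen gives a 1.9-fold higher number from compound 2 to compound 3 (0.27 log units; within the scatter) in this assay. The entering group counts 2 hydrogen-bond donors against 1, yet the dog dose read-out does not separate the two groups. No measurement of any property bears on this result. The compounds shown leave open how an ether oxygen or a methylene group would read at this place, and whether the exchange would read the same with the pendant groups of compound 1.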